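Lengthening an alkoxy group on a charged purine-type cytotoxic agent

A few compounds are considered here, and "the series" means these few. Any claim that something is new, unique, unknown or untested is made for them only; others in the source may bear on it.

Measured so far in a functional assay on cells (Homo sapiens) for cytotoxicity; a lower number here means a stronger inhibitor, a higher number a weaker inhibitor:
- compound 1, `CO/N=c1\[nH]cnc2c1[n+](C/C=C(\C)CC/C=C(\C)CC/C=C(\C)CCC=C(C)C)cn2C(c1ccccc1)c1ccccc1`, giving 2600 nM
- compound 2, `CO/N=c1\[nH]cnc2c1[n+](C/C=C(\C)CCCC(C)CCCC(C)CCCC(C)C)cn2C`, giving 3750 nM

Compound 2 has the higher of these two numbers, but its gap to compound 1 lies within the scatter of repeat measurements, so the two cannot be placed in order. Compound 3, `C/C(=C\C[n+]1cn(C)c2nc[nH]/c(=N\OCc3ccccc3)c21)CCCC(C)CCCC(C)CCCC(C)C`, keeps the whole of compound 2 except for one change: phenyl in place of hydrogen on a saturated chain carbon bound to an oxygen. Read one bond further out, a methoxy group becomes a benzyloxy group. For the measured compounds named here, no pair of measured compounds shows this change alone, so the size and direction of the step are not known from the data. In this assay compound 3 is expected to land close to compound 2, with the step of a 1.3-fold lower number from compound 2 to compound 3 (0.10 log units; within the scatter) estimated to stay within the usual scatter rather than clearly beyond it. For compound 3 the estimated value is 3000 nM, with a range from 1200 nM to 8000 nM.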

Compound 3, half-maximal inhibitory concentration: 7070 nM
The estimate for compound 3 lay 2.4-fold (0.37 log units) below the measured number; measured number inside the range.
By their numbers in this assay, from the lowest: compounds 1, 2 and 3 (each within the scatter of the next, the first and the last beyond it).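

In this assay, for the compounds shown here, the swap of methoxy for benzyloxy on an otherwise unchanged compound gives the first direct reading of this change: a 1.9-fold higher number from compound 2 to compound 3 (0.28 log units; within the scatter). A phenyl group, with its six added carbon atoms, can therefore stand on this saturated chain carbon bound to an oxygen without the number moving clearly beyond the usual scatter, so compound 2 and compound 3 cannot be placed in order. Nothing available here offers an explanation for this outcome.

On these data alone, it remains open whether a different group at this place, such as an ethoxy group, a longer chain ending in an amine, or a carboxylic acid, would shift the number beyond the scatter. As far as these compounds go, it is also open whether benzyloxy would give a similar step on the core of compound 1, with its different chain and its diphenylmethyl group.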